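The source may report more compounds than this note shows. Statements on the series, on what has been measured and on what is new or still open speak of the compounds shown alone.

Three compounds were measured in a functional assay on HCT-116 cells (Homo sapiens) for cytotoxicity, read by MTT assay, with a stated time of 72 h (a higher number here means a weaker inhibitor, a lower number a stronger inhibitor), as follows

- Compound 1 `O=C1C=CCC/C1=C\C=C\c1ccccc1` gives 5400 nM
- Compound 2 `Cc1ccc(/C=C/C=C2\CCC=CC2=O)cc1` gives 7200 nM
- Compound 3 `O=C1C=CCC/C1=C\C=C\c1ccccc1[N+](=O)[O-]` gives 6200 nM

Compound 3, at 6200 nM in this assay, stands level with the other two, since its value lies within the scatter of both compound 1 and compound 2. The next compound, compound 4 `COc1ccccc1/C=C/C=C1\CCC=CC1=O`, carries methoxy in place of nitro on an aromatic carbon, ortho to a large group (methoxy in place of nitro on an aromatic carbon). For the measured compounds named here, no measured compound carries methoxy, and no measured step makes this exchange directly. Going by the values given here, two measured steps bear on it, each changing the same aromatic ring: methyl in place of hydrogen (a 1.3-fold higher number from compound 1 to compound 2 (0.12 log units; within the scatter)) and nitro in place of hydrogen (a 1.1-fold higher number from compound 1 to compound 3 (0.06 log units; within the scatter)). Both lie within the scatter, so a substituent on this ring has not yet moved the number measurably. No step beyond the scatter is therefore expected here, and the estimated change is a 1.0-fold lower number from compound 3 to compound 4 (0.01 log units; within the scatter) in this assay. For compound 4 the expected value is 6000 nM, with an estimated range of 3000 nM to 12000 nM.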

Compound 4, half-maximal inhibitory concentration: 2800 nM
Compound 4: middle estimate off by 2.1-fold (0.33 log units), on the high side; the whole stated range lies above it.
By their numbers in this assay, from the lowest: compounds 4, 1, 3 and 2 (each within the scatter of the next, the first and the last beyond it).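

In this assay, for the compounds shown here, the exchange of nitro for methoxy on this aromatic carbon, ortho to a large group, gives a 2.2-fold lower number from compound 3 to compound 4 (0.35 log units; beyond the scatter) and is the first step on this ring to pass beyond the scatter. Set against hydrogen, the same methoxy gives a 1.9-fold lower number from compound 1 to compound 4 (0.29 log units; within the scatter) and stays within the scatter, so the ring has so far shown a measurable difference only between methoxy and nitro, not between methoxy and the unsubstituted ring. Nothing measured here accounts for that difference.

The compounds shown leave open whether an amine or a hydroxyl group on this aromatic carbon would stand with methoxy or with nitro. They also leave open whether methoxy elsewhere on the ring, or a longer chain such as ethoxy in its place, would keep the lower number.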